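Furan to thiophene: a heteroaryl swap on a steroid-like core

A few compounds are considered here, and "the series" means these few. Any claim that something is new, unique, unknown or untested is made for them only; others in the source may bear on it.

Measured compounds:
- Compound 1, `C=C1CC[C@@H]2[C@](C)(CNCc3ccc(C#N)cc3)[C@H](O)CC[C@@]2(C)[C@@H]1/C=C/C1=CCOC1=O`: 1130 nM
- Compound 2, `C=C1CC[C@@H]2[C@](C)(CNCc3ccco3)[C@H](O)CC[C@@]2(C)[C@@H]1/C=C/C1=CCOC1=O`: 1830 nM

In a functional assay on BMMC cells (Mus musculus, strain C57BL/6) for inhibition, with stated times of 5 days and 48 h (a higher number here means a weaker inhibitor, a lower number a stronger inhibitor), compound 2 gives 1830 nM, the highest of the two numbers; compound 1 is within the scatter of it, as the step of a 1.6-fold higher number from compound 1 to compound 2 (0.21 log units; within the scatter) shows. Compound 3, `C=C1CC[C@@H]2[C@](C)(CNCc3cccs3)[C@H](O)CC[C@@]2(C)[C@@H]1/C=C/C1=CCOC1=O`, differs from compound 2 only by thiophen-2-yl in place of furan-2-yl on a saturated chain carbon bound to an amine nitrogen. Going by the values given here, no measured step covers this exact exchange. Because a 1.6-fold higher number from compound 1 to compound 2 (0.21 log units; within the scatter) stays within the scatter, the step expected for compound 3 is a 1.2-fold lower number from compound 2 to compound 3 (0.09 log units; within the scatter). The estimate for compound 3 is 1500 nM, between 700 nM and 3200 nM.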

Compound 3, half-maximal inhibitory concentration: 1070 nM
For compound 3 the middle estimate is 1.4-fold (0.15 log units) above the measured one; the measured number falls inside the stated range.
By their numbers in this assay, from the lowest: compounds 3, 1 and 2 (each within the scatter of the next).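

In this assay the swap of furan-2-yl for thiophen-2-yl gives a 1.7-fold lower number from compound 2 to compound 3 (0.23 log units; within the scatter) on the same saturated chain carbon bound to an amine nitrogen. Exchanging 4-cyanophenyl for thiophen-2-yl gives a 1.1-fold lower number from compound 1 to compound 3 (0.02 log units; within the scatter) at that place, so the three aromatic groups shown cannot be told apart in this read-out. No measurement is available that would explain these numbers. Still open, from the compounds shown here alone, is whether a group without an aromatic ring, such as a longer chain ending in a carboxylic acid, would give a similar number. Also open, going by these compounds, is whether any group here can move the number beyond the scatter.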